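Amide replacement on the cinnamoyl-pyridine series

A few compounds are considered here, and "the series" means these few. Any claim that something is new, unique, unknown or untested is made for them only; others in the source may bear on it.

Measured compounds:
compound 1, `COC1CN(C(=O)/C=C/c2ccncc2-c2ccc(F)cc2)C1`: "not determined" (no result reported)
compound 2, `CCOC(=O)/C=C/c1ccncc1-c1ccc2cc[nH]c2c1`: 12.1 nM

In an assay on a protein complex for inhibition of CDK8/Cyclin C (Homo sapiens), with a stated time of 1 h (on this read-out higher numbers stand for weaker inhibition and lower numbers for stronger inhibition), compound 1 gives "not determined" (no result reported), so compound 1 stands without a number. In this assay compound 2 gives 12.1 nM, the only result in hand. Compound 3, `CN1CCN(C(=O)/C=C/c2ccncc2-c2ccc(F)cc2)CC1`, carries 4-methylpiperazin-1-yl in place of 3-methoxyazetidin-1-yl on a carbonyl carbon, in words 4-methylpiperazin-1-yl in place of 3-methoxyazetidin-1-yl on a carbonyl carbon. With no number for compound 1, no size or direction of this step can be read from the data; a change of no more than the scatter is expected. Compound 3 is expected at 30 nM, with a range from 6 nM to 200 nM.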

Compound 3, half-maximal inhibitory concentration: 1210 nM
The estimate for compound 3 lay 40-fold (1.61 log units) below the measured number; measured number outside the range, above it.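

Within the data shown here, compound 1 has no number, so no step from compound 1 to compound 3 can be read. The compounds shown leave open how 3-methoxyazetidin-1-yl and 4-methylpiperazin-1-yl compare on the shared core. No other data bear on this result.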